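A trifluoromethyl swap on a short-lived compound

The compounds below may be only part of what the source reports. "The series", "measured", "known", "first", "only" and "open" are said of these compounds alone.

Among the measured compounds shown here, in a physicochemical assay for pharmacokinetics, at pH 6 (on this read-out higher numbers stand for a longer-lived compound and lower numbers for a shorter-lived compound), compound 1 `O=C(Sc1cccnc1C(=O)O)c1ccccc1` gives 21.1 h, while compound 2 `O=C(Sc1cccnc1C(=O)O)c1cccc(Cl)c1` gives 4.7 h, the lower of the two numbers so far. The unmeasured compound 3 `O=C(Sc1cccnc1C(=O)O)c1cccc(C(F)(F)F)c1` differs from compound 2 in one place: trifluoromethyl in place of chloro on an aromatic carbon. Put simply, this is trifluoromethyl in place of chloro on an aromatic carbon, meta to a large group.

For the measured compounds named here, only one measured step bears on this change. Chloro in place of hydrogen gave a 4.5-fold lower number from compound 1 to compound 2 (0.65 log units; beyond the scatter), a modest step that involved no trifluoromethyl, so it is only a loose guide. Going by that step, a small further drop is expected in this assay, possibly no larger than the usual scatter. The expected step is a 1.5-fold lower number from compound 2 to compound 3 (0.17 log units; within the scatter). The estimate for compound 3 is 3.2 h, with an expected range from 1.5 h to 6.5 h.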

Compound 3, half-life: 3.9 h
Compound 3: middle estimate off by 1.2-fold (0.09 log units), on the low side; low and high end bracket the measured number.
By their numbers in this assay, from the lowest: compounds 3 and 2 (each within the scatter of the next); then compound 1.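

In this assay, trifluoromethyl in place of chloro gives a 1.2-fold lower number from compound 2 to compound 3 (0.08 log units; within the scatter), so this position does not separate the two groups, even though trifluoromethyl brings 4 heavy atoms where chloro brings 1. Trifluoromethyl in place of hydrogen gives a 5.4-fold lower number from compound 1 to compound 3 (0.73 log units; beyond the scatter), a step beyond the scatter. Among these three compounds, then, both groups at this position go with a shorter half-life than hydrogen, and no compound shown goes against that.

From the compounds shown here alone, whether an amine or a methoxy group at this position would also go with a shorter half-life stays open, as does whether chloro and trifluoromethyl would still match elsewhere on the aromatic ring. No measurement at hand explains why these two groups give such similar numbers.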